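The source may report more compounds than this note shows. Statements on the series, on what has been measured and on what is new or still open speak of the compounds shown alone.

In an ADME assay on Huh-7 cells (Homo sapiens) for cytotoxicity, read by MTT assay, with a stated time of 72 h (a higher number here means that more compound is tolerated, a lower number that less compound is tolerated), three compounds sharing one core have been measured: compound 1 `Cc1cc(=O)oc2cc(OCc3cn(-c4ccc(F)cc4)nn3)ccc12`, compound 2 `Cc1cc(=O)oc2cc(OCc3cn(-c4ccccc4Cl)nn3)ccc12` and compound 3 `Cc1cc(=O)oc2cc(OCc3cn(-c4ccccc4[N+](=O)[O-])nn3)ccc12`. Compound 1 gives > 100 ug/mL, which is a limit of the assay and not a number. Compound 2 gives > 100 ug/mL, again a limit. Compound 3 gives > 100 ug/mL, also a limit. The whole set thus stands at one mark: the limit of > 100 ug/mL in this assay, at which 3 of the 3 values shown sit.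

The next compound, compound 4 `Cc1cc(=O)oc2cc(OCc3cn(CCO)nn3)ccc12`, carries 2-hydroxyethyl in place of 2-nitrophenyl on an aromatic nitrogen. The measured steps that bear on this change are a step that the two limits leave unreadable from compound 1 to compound 2, a step that the two limits leave unreadable from compound 1 to compound 3 and a step that the two limits leave unreadable from compound 2 to compound 3. All three compare groups with a six-membered aromatic ring, whereas the entering group has no ring, and none of the three has a readable size. They offer no direction, so no change beyond the usual scatter is expected in this assay, and the estimate is a step that the limit leaves unreadable from compound 3 to compound 4. Compound 4 is estimated at 130 ug/mL, with an expected range from 60 ug/mL to 300 ug/mL.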

Compound 4, half-maximal cytotoxic concentration: > 100 ug/mL
Compound 4: no number, only a limit; the forecaster's own chance of this, stated with the estimate: 80%; the middle value lies beyond the limit too.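

Compound 4 gives > 100 ug/mL, again a limit and not a number. Going by these compounds alone, no step from compound 1, compound 2 or compound 3 to compound 4 can be read. How much of each compound is tolerated, and whether swapping the group on the aromatic nitrogen changes that, stays open, since all four stand at one mark: the limit of > 100 ug/mL in this assay, at which 4 of the 4 values shown sit.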